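The compounds below may be only part of what the source reports. "The series", "measured", "known", "first", "only" and "open" are said of these compounds alone.

In a functional assay on HCT-15 cells (Homo sapiens) for cytotoxicity, read by sulforhodamine B assay, with a stated time of 48 h, tested at 0.1 uM (a higher number here means a weaker effect of the compound at the concentration tested, a lower number a stronger effect), compound 2 `COc1ccc(C(=O)/C=C/c2cc(-c3cc(OC)c(OC)c(OC)c3)n[nH]2)cc1` gives 100%, the highest of the two numbers recorded here. Going by the values given here, its only measured neighbour is compound 1 `COc1ccc(C(=O)/C=C/c2cc(-c3cc(OC)c(OC)c(OC)c3)n[nH]2)cc1OC`, which in this assay gives 98%; the step of a number 2 percentage points higher from compound 1 to compound 2 (within the scatter) tells of no shift. Compound 3 `COc1cc(-c2cc(/C=C/C(=O)c3ccc(F)c(F)c3)[nH]n2)cc(OC)c1OC` differs from compound 2 by 3,4-difluorophenyl in place of 4-methoxyphenyl on a carbonyl carbon. Among the compounds with values here, the one measured step also exchanges a substituent on the aromatic ring attached to the carbonyl carbon, yet it stayed within the scatter, and nothing measured speaks to 3,4-difluorophenyl in place of 4-methoxyphenyl. The expected step is therefore a number 3 percentage points lower from compound 2 to compound 3 (within the scatter), none beyond the scatter. Compound 3 is estimated at 97%, between 84% and 106%.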

Compound 3, a percentage reported as activity, at one concentration (the size of the read-out at that concentration, not a potency): 95%
Compound 3: middle estimate off by 2 percentage points, on the high side, within the range that was stated.
By their numbers in this assay, from the lowest: compounds 3, 1 and 2 (each within the scatter of the next).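

In this assay the change now replaces the whole phenyl group on the carbonyl carbon, with methoxy giving way to fluorine, and the read-out stays within the scatter: 3,4-difluorophenyl in place of 4-methoxyphenyl (a number 5 percentage points lower from compound 2 to compound 3 (within the scatter)) and 3,4-difluorophenyl in place of 3,4-dimethoxyphenyl (a number 3 percentage points lower from compound 1 to compound 3 (within the scatter)). At this position and this single concentration, the methoxy-bearing and fluorine-bearing phenyl groups are thus not told apart. No available evidence bears on this result. On these data alone, it remains open whether an amine or a carboxylic acid on this phenyl ring, or a pyridine ring in its place, would shift the read-out.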